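Carboxy for Hydroxy on a Quinoline Amide Scaffold

This account rests on a few compounds, and the source may have more. Where it says the series, first, only, none or still open, it means among the compounds named here.

The set contains three measured compounds, compound 1 `Cc1c(C(=O)Nc2c(F)cc(-c3cccc(F)c3)cc2F)nc2ccc(F)cc2c1O`, compound 2 `COc1ccc2nc(C(=O)Nc3ccc(-c4ccccc4)cc3)c(C)c(O)c2c1` and compound 3 `Cc1c(C(=O)Nc2c(F)cc(-c3cccc(F)c3)cc2F)nc2ccc(F)cc2c1C(=O)O`, together with the unmeasured compound 4 `COc1ccc2nc(C(=O)Nc3ccc(-c4ccccc4)cc3)c(C)c(C(=O)O)c2c1`. In a functional assay on Hep 3B2 cells (Homo sapiens) for antiproliferative activity, read by MTT assay, with a stated time of 24 h, tested at 0.14 ug/mL (on this read-out lower numbers stand for a weaker effect and higher numbers for a stronger effect at the one concentration tested), compound 1 gives 2.65%, compound 2 gives 3.52% and compound 3 gives 0.65%; the three numbers lie within the scatter of one another. Compound 3 differs from compound 1 by carboxy in place of hydroxy on an aromatic carbon, a change that made a number 2 percentage points lower from compound 1 to compound 3 (within the scatter). The difference between the cores of compound 1 and compound 2 is not broken down here. Compound 4 differs from compound 2 by carboxy in place of hydroxy on an aromatic carbon, the same change seen earlier. Because the earlier step of a number 2 percentage points lower from compound 1 to compound 3 (within the scatter) stayed within the scatter, the step from compound 2 to compound 4 is expected to be similar in size, a number 1.7 percentage points lower from compound 2 to compound 4 (within the scatter). Compound 4 is therefore estimated at 1.8%, between 0% and 6%.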

Compound 4, a percentage reported as inhibition, at one concentration (the size of the read-out at that concentration, not a potency): 2.01%
Compound 4: the middle estimate sits 0.2 percentage points below what was measured; low and high end bracket the measured number.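

In this assay, carboxy in place of hydroxy on an aromatic carbon gave a number 1.5 percentage points lower from compound 2 to compound 4 (within the scatter). Set beside the earlier step, the change reads alike on both cores: the same change on two cores in this assay, a number 2 percentage points lower (within the scatter) from compound 1 to compound 3 and a number 1.5 percentage points lower (within the scatter) from compound 2 to compound 4, 0.5 percentage points apart, within the scatter of two such steps. Going by these compounds alone, this shows only that neither core gave a step distinguishable from the scatter; it does not show that the change has a real effect that carries from one core to the other.

The compounds shown leave open whether an amine or a nitrile on that same aromatic carbon, opposite the ring nitrogen, would give a step beyond the scatter. They also leave open how the change would read on a core with a much larger number in this assay.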